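The compounds below may be only part of what the source reports. "The series", "measured", "known", "first", "only" and "open" are said of these compounds alone.

Measured compounds:
- compound 1 `O=C1C=C(Nc2cccc(F)c2)C(=O)c2c1nc1n2[C@H]2OC[C@@H](O)[C@H]2OC1`: 7030 nM
- compound 2 `O=C1C(Nc2ccc(C(F)(F)F)cc2)=CC(=O)c2c1nc1n2[C@H]2OC[C@@H](O)[C@H]2OC1`: 2250 nM

Both compounds were tested in a functional assay on ECa-109 cells for inhibition, with ECa-109 cell line (Homo sapiens) as the target, read by sulforhodamine B assay; on this read-out lower numbers stand for stronger inhibition and higher numbers for weaker inhibition. Compound 1 gives 7030 nM there, and compound 2 gives 2250 nM. Of the two numbers, that of compound 1 is the higher, and the gap to compound 2 is beyond the usual scatter, so compound 1 is the weaker inhibitor of this pair. The two compounds differ in more than one place, so their values alone do not tell which part of the difference matters.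

The unmeasured compound 3 `COc1cccc(NC2=CC(=O)c3nc4n(c3C2=O)[C@H]2OC[C@@H](O)[C@H]2OC4)c1` keeps the shared core of compound 1 and differs from it in one place only: methoxy in place of fluoro on an aromatic carbon. Going by the values given here, no measured pair shows this exchange on its own, so the size of its effect is not known from these data. A change of this kind is expected to move the number only modestly, so the step from compound 1 to compound 3 is estimated at a 1.4-fold lower number from compound 1 to compound 3 (0.15 log units; within the scatter), that is within the scatter or close to it. Compound 3 is therefore expected to give about 5000 nM in this assay, within a range of 1500 nM to 16000 nM.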

Compound 3, half-maximal inhibitory concentration: 7620 nM
The estimate for compound 3 lay 1.5-fold (0.18 log units) below the measured number; low and high end bracket the measured number.
By their numbers in this assay, from the lowest: compound 2; then compounds 1 and 3 (each within the scatter of the next).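

In this assay the exchange of fluoro for methoxy on this aromatic carbon gives a 1.1-fold higher number from compound 1 to compound 3 (0.03 log units; within the scatter) and so stays within the usual scatter of repeated measurements. Going by these compounds alone, this is the first comparison here in which only one place differs, and it shows that at this position of the 3-fluorophenyl ring, methoxy, with two heavy atoms and a hydrogen-bond acceptor, reads the same in this cell assay as fluoro, with one heavy atom and no hydrogen-bond acceptor. Nothing in the data explains why these two groups read alike.

The compounds shown leave open whether the same position would also accept a group of a different kind, such as an amine, a carboxylic acid or a longer alkoxy chain, or whether the flat result holds only for small groups like these two. From the compounds shown here alone, it also remains open whether the exchange of fluoro for methoxy would give the same result at another carbon of the ring.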